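The source may hold more compounds than are shown below. What is called first, only, known or untested is meant among the compounds shown, and "the series" means these compounds.

In a functional assay on BXPC-3 cells (Homo sapiens) for antiproliferative activity, read by sulforhodamine B assay, with a stated time of 72 h (a lower number here means a stronger inhibitor, a higher number a weaker inhibitor), compound 1 (`O=C(c1ccccc1)c1cccc(/C=c2\[nH]c(=O)/c(=C/c3ccccn3)[nH]c2=O)c1`) gives 6.27 nM and compound 2 (`CC(C)(C)c1[nH]cnc1/C=c1\[nH]c(=O)/c(=C/c2cccc(C(=O)c3ccncc3)c2)[nH]c1=O`) gives 23.8 nM as the higher of the two numbers. Compound 2 is therefore the weaker inhibitor of this pair, and the gap lies beyond the usual scatter of repeated measurements. The two compounds differ in more than one place, so this gap cannot be tied to any single group.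

Compound 3 (`CC(C)(C)c1[nH]cnc1/C=c1\[nH]c(=O)/c(=C/c2cccc(C(=O)c3cc[nH]c3)c2)[nH]c1=O`) has not yet been measured. It departs from compound 2 in one place (1H-pyrrol-3-yl in place of pyridin-4-yl on a carbonyl carbon), with 1H-pyrrol-3-yl in place of pyridin-4-yl on a carbonyl carbon. Within the data shown here, no measured pair shows this exchange, so the data offer no direct guide to its effect, and the expectation rests only on how much of compound 2 stays unchanged. No shift beyond the scatter is expected in either direction, and the estimated change is a 1.2-fold lower number from compound 2 to compound 3 (0.08 log units; within the scatter) in a slightly stronger direction. For compound 3 the estimated value is 20 nM with an expected range from 6 nM to 70 nM in this measurement.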

Compound 3, half-maximal inhibitory concentration: > 100 nM
Compound 3: only a limit was reported; the forecaster's own chance of this, stated with the estimate: 3%; middle value at least 5.0-fold (0.69 log units) away from the limit.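

Compound 3 gives > 100 nM in this assay, and this is a limit of the assay, not a number. Among these compounds, replacing pyridin-4-yl with 1H-pyrrol-3-yl on a carbonyl carbon, with the other neighbour of that carbonyl an aromatic carbon, brings an at least 4.2-fold higher number from compound 2 to compound 3 (0.62 log units; beyond the scatter), which is the first evidence that activity at this position depends on which ring is attached. The step gives only a minimum size, and how far compound 3 lies past the limit cannot be read from the data: the limit of > 100 nM in this assay, at which 1 of the 3 values shown sits.

The exchange changes several things at once: a six-membered aromatic ring gives way to a five-membered one, and the hydrogen-bond acceptor that leaves is replaced by a hydrogen-bond donor, so the compounds shown do not separate these differences. A furan-3-yl on the same carbonyl carbon would keep the five-membered ring without the ring hydrogen of the pyrrole, while a small alkyl group such as methyl in that place would test whether any aromatic ring is needed there at all.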